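Swapping an isopentyl amide for a benzothiazole amide

This account rests on a few compounds, and the source may have more. Where it says the series, first, only, none or still open, it means among the compounds named here.

Three compounds share a core in which an amino-acid-like fragment is joined to a piperidine bearing a chlorophenyl group. Compound 1, `CC(C)CCC(=O)N[C@@H](C(=O)N1CCC(c2ccc(Cl)cc2)CC1)C(C)C`, gives 26 nM in an assay on THP-1 cells for displacement of a labelled ligand from C-C chemokine receptor type 1 (Homo sapiens) (a lower number here means a stronger inhibitor, a higher number a weaker inhibitor), and so has the lowest number of the three. Compound 3, `CC[C@@H](NC(=O)CC(C)C)C(=O)N1CCC(c2ccc(Cl)cc2)CC1`, gives 152 nM in this assay, and compound 2, `CC(C)C(NS(=O)(=O)Cc1ccccc1)C(=O)N1CCC(c2ccc(Cl)cc2)CC1`, gives 303 nM; both of these differences from compound 1 lie beyond the usual scatter, so compound 1 stands as the strongest binder of the measured set.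

Compound 4, `CC(C)[C@@H](NC(=O)c1nc2ccccc2s1)C(=O)N1CCC(c2ccc(Cl)cc2)CC1`, is not yet measured. It is built from compound 1 by one change: 1,3-benzothiazol-2-yl in place of isopentyl on a carbonyl carbon. Within the data shown here, none of the measured pairs differs in exactly this way, so no earlier step tells how much the number should move. The change is expected to cost a little, with a step of a 2.3-fold higher number from compound 1 to compound 4 (0.36 log units; beyond the scatter) in this assay that may or may not clear the scatter. For compound 4 the estimated value is 60 nM, within a range of 12 nM to 350 nM.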

Compound 4, half-maximal inhibitory concentration: 18 nM
Compound 4: middle estimate off by 3.3-fold (0.52 log units), on the high side; measured number inside the range.
By their numbers in this assay, from the lowest: compounds 4 and 1 (each within the scatter of the next); then compounds 3 and 2 (each within the scatter of the next).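

In this assay, putting 1,3-benzothiazol-2-yl in place of isopentyl on this carbonyl carbon gives a 1.4-fold lower number from compound 1 to compound 4 (0.16 log units; within the scatter), so the two compounds cannot be told apart. This position therefore accepts both a chain with no ring and a larger group with a five-membered and a six-membered aromatic ring, which also brings hydrogen-bond acceptors that isopentyl lacks, with no step beyond the scatter. Nothing measured here explains why these two different groups give such similar numbers.

The compounds shown leave open how a chain ending in an amine or a carboxylic acid would behave on this carbonyl carbon, and whether a single phenyl ring would serve as well. They also leave open whether the same swap would give a similar step on the core of compound 3.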